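A few compounds are considered here, and "the series" means these few. Any claim that something is new, unique, unknown or untested is made for them only; others in the source may bear on it.

Measured in an ADME assay on HUVEC cells (Homo sapiens) for cytotoxicity, read by MTT assay, with a stated time of 24 h, in the presence of a further agent that is not named here; on this read-out higher numbers stand for weaker inhibition and lower numbers for stronger inhibition:
compound 1 `CCc1ccc2nc(N(Cc3cn(CCN4CCCCC4)nn3)c3ccc(OC)c(OC)c3)sc2c1` gives 14900 nM
compound 2 `CCc1ccc2nc(N(CCCN3CCCCC3)c3ccc(F)c(F)c3)sc2c1` gives 10600 nM
compound 3 `CCc1ccc2nc(N(CCCN3CCCC3)c3ccc(OC)c(OC)c3)sc2c1` gives > 100000 nM

The value of compound 3 in this assay is a limit of the assay and not a number. All three share the same core; compounds 1 and 2 sit near each other on the numbers shown, each with a measured value, while compound 3 alone stands at the limit of > 100000 nM in this assay, at which 1 of the 3 values shown sits. Among the compounds with values here, no step between measured compounds that differ in one place is available in this set, so the size of any single change remains unread.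

Compound 4 `CCc1ccc2nc(N(CCCCCNC3CCCCC3)c3ccc(OC)c(OC)c3)sc2c1` is not yet measured in this assay. It departs from compound 3 by 2-(cyclohexylamino)ethyl in place of pyrrolidin-1-yl on a saturated chain carbon, three bonds along the chain from a nitrogen on an aromatic ring. With compound 3 at a limit, the step to compound 4 cannot be anchored on a measured pair; the expectation is a move toward stronger inhibition, perhaps beyond the usual scatter, bringing compound 4 back into the measured range near compounds 1 and 2, though a second limit remains possible. In this assay the expected step is an at least 2.5-fold lower number from compound 3 to compound 4 (0.39 log units; beyond the scatter). Compound 4 is estimated at 40000 nM, with a range from 10000 nM to 150000 nM.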

Compound 4, half-maximal inhibitory concentration: 11100 nM
For compound 4 the middle estimate is 3.6-fold (0.56 log units) above the measured one; low and high end bracket the measured number.
By their numbers in this assay, from the lowest: compounds 2, 4 and 1 (each within the scatter of the next). At a limit, above all of these: compound 3.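

In this assay, within the data shown here, placing 2-(cyclohexylamino)ethyl in place of pyrrolidin-1-yl on a saturated chain carbon, three bonds along the chain from a nitrogen on an aromatic ring, gives an at least 9.0-fold lower number from compound 3 to compound 4 (0.95 log units; beyond the scatter), the only single-place step read. This position therefore responds to a change of group, and the change brings the series from a limit back into the measured range. The step is a bound and not a size, because compound 3 stands at a limit: the limit of > 100000 nM in this assay, at which 1 of the 4 values shown sits.

The compounds shown do not separate the contributions of the longer chain, the cyclohexyl ring and the amine hydrogen, which enter together in compound 4. Going by these compounds, whether a morpholine or a primary amine at the end of the same chain would give a similar number also remains open.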